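The source may report more compounds than this note shows. Statements on the series, on what has been measured and on what is new or still open speak of the compounds shown alone.

Measured in a functional assay on MIA PaCa-2 cells (Homo sapiens) for cytotoxicity, read by fluorescence, with a stated time of 48 h; a higher number here means that more compound is needed for the effect, a lower number that less compound is needed:
- compound 1 `CC(C)=CCC/C(C)=C/CC/C(C)=C/CSC[C@H](NC(=O)CCCCCN1CCN(C)CC1)C(=O)NC1CCCCCC1`: 2700 nM
- compound 2 `CC(C)=CCC/C(C)=C/CC/C(C)=C/CSC[C@H](NC(=O)CCCCCN1CCCC1)C(=O)NC1CCCCC1`: 5600 nM
- compound 3 `CC(C)=CCC/C(C)=C/CC/C(C)=C/CSC[C@H](NC(=O)CCCCCN1CCN(C)CC1)C(=O)NC1CCCC1`: 10900 nM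

Compound 3 gives 10900 nM, which lies within the scatter of compound 2 at 5600 nM. The gap to compound 1 is beyond the scatter: a 4.0-fold higher number from compound 1 to compound 3 (0.61 log units; beyond the scatter).

The next structure is compound 4 `CC(C)=CCC/C(C)=C/CC/C(C)=C/CSC[C@H](NC(=O)CCCCCN1CCN(C)CC1)C(=O)NC1CCCCC1`, with cyclohexyl in place of cyclopentyl on an amide-type nitrogen.

Within the data shown here, the one measured step at this place is the modest one above, where cyclopentyl replaces cycloheptyl. Cyclohexyl has a ring size that falls inside that measured range, so only part of that step is expected to be recovered, towards a lower number. Compound 2 also carries cyclohexyl on the amide-type nitrogen but differs elsewhere, and its 5600 nM is a loose guide only.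

The expected change is a 2.2-fold lower number from compound 3 to compound 4 (0.34 log units; beyond the scatter), close to the edge of the scatter. For compound 4 the estimate is 5000 nM, with an expected range of 2500 nM to 10000 nM.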

Compound 4, half-maximal effective concentration: 5900 nM
The estimate for compound 4 lay 1.2-fold (0.07 log units) below the measured number; the range from low to high includes it.
By their numbers in this assay, from the lowest: compound 1; then compounds 2, 4 and 3 (each within the scatter of the next).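

In this assay the cyclopentyl to cyclohexyl change gives a 1.8-fold lower number from compound 3 to compound 4 (0.27 log units; within the scatter), so these two rings on the amide-type nitrogen cannot be told apart, while cycloheptyl does separate from cyclohexyl, with a 2.2-fold higher number from compound 1 to compound 4 (0.34 log units; beyond the scatter). Among the 4-methylpiperazin-1-yl compounds, only the cycloheptyl amide therefore stands apart, and that gap is modest. The new pair at the saturated chain carbon gives a 1.1-fold higher number from compound 2 to compound 4 (0.02 log units; within the scatter), so with cyclohexyl on the amide-type nitrogen, 4-methylpiperazin-1-yl and pyrrolidin-1-yl cannot be told apart.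

Still open, as far as these compounds go, is whether a cyclooctyl or phenyl group on the amide-type nitrogen would follow cycloheptyl, and whether pyrrolidin-1-yl and 4-methylpiperazin-1-yl would also stay together with cycloheptyl there. Nothing at hand accounts for these results.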